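The source may report more compounds than this note shows. Statements on the series, on what has been measured and on what is new or still open speak of the compounds shown alone.

Measured compounds:
Compound 1, `C=C(C)Cn1cc(/C=C/C(=O)CC(=O)C(=O)OCC)c2ccccc21`, in an assay on isolated protein for inhibition of DNA nucleotidylexotransferase (Homo sapiens), read by scintillation counting, with a stated time of 10 min (on this read-out higher numbers stand for weaker inhibition and lower numbers for stronger inhibition), compound 1 gives > 40 uM.
Compound 2, `CC(C)CCn1cc(/C=C/C(=O)CC(=O)C(=O)O)c2ccccc21`, in this assay compound 2 gives 16.3 uM.

The value of compound 1 is a limit of the assay and not a number, and it matches (the limit of > 40 uM in this assay, at which 1 of the 2 values shown sits). Compound 2 therefore stands as the only measured number in this assay, with the other shown value being a limit. Among the compounds with values here, no step between two measured compounds is available here.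

Compound 3, `C=C(C)Cn1cc(/C=C/C(=O)CC(=O)C(=O)O)c2ccccc21`, has not yet been measured in this assay. It differs from compound 2 by 1-methylethenyl in place of isobutyl on a saturated chain carbon bound to an aromatic nitrogen. With nothing shown for a change of this kind, the step from compound 2 to compound 3 in this assay, a 1.5-fold higher number from compound 2 to compound 3 (0.19 log units; within the scatter), is expected to be small, at most a modest loss and possibly none beyond the usual scatter. Compound 3 is accordingly estimated at about 25 uM, within a range from 8 uM to 60 uM.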

Compound 3, concentration for 50% inhibition: 2.5 uM
The estimate for compound 3 lay 10-fold (1.00 log units) above the measured number; the whole stated range lies above it.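

In this assay, the position on a saturated chain carbon bound to an aromatic nitrogen proves sensitive to the group it carries: 1-methylethenyl in place of isobutyl brings a 6.5-fold lower number from compound 2 to compound 3 (0.81 log units; beyond the scatter), so exchanging this saturated branch for an unsaturated one changes the read-out beyond the scatter. With 1-methylethenyl held in place, hydrogen in place of ethyl on an oxygen next to a carbonyl group brings an at least 16-fold lower number from compound 1 to compound 3 (1.20 log units; beyond the scatter), which shows that this second site also matters in this assay. Compound 1 stands at a limit of the assay and not at a number, so the true size of that second step stays unknown: the limit of > 40 uM in this assay, at which 1 of the 3 values shown sits.

Nothing shown gives a reason for either step. On these data alone, it remains open whether the double bond itself or the shorter chain accounts for the first step, which a saturated isobutyl-free chain such as n-propyl, a longer chain or a benzyl group on the nitrogen could separate, and whether an amide or a methyl ester in place of the carboxylic acid would behave like the ethyl ester of compound 1.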